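A few compounds are considered here, and "the series" means these few. Any claim that something is new, unique, unknown or untested is made for them only; others in the source may bear on it.

Measured so far:
Compound 1, `CCCCOC(=O)CCC(=O)N1CCN(CCCOc2cc3c(Nc4ccc(F)c(Cl)c4)ncnc3cc2OC)CC1`: 94.4%
Compound 2, `CCCCCOC(=O)CCC(=O)N1CCN(CCCOc2cc3c(Nc4ccc(F)c(Cl)c4)ncnc3cc2OC)CC1`: 87.1%
Compound 3, `CCCCCCCOC(=O)CCC(=O)N1CCN(CCCOc2cc3c(Nc4ccc(F)c(Cl)c4)ncnc3cc2OC)CC1`: 89.1%

All three were tested in a functional assay on A549 cells (Homo sapiens) for cytotoxicity, read by MTT assay, with a stated time of 24 h, tested at 10 uM; on this read-out higher numbers stand for a weaker effect at the one concentration tested and lower numbers for a stronger effect. They share one core and differ only in the length of a saturated chain that ends at an oxygen next to a carbonyl group. Between compound 1 and compound 2 the change is methyl in place of hydrogen on a saturated chain carbon, four bonds along the chain from an oxygen next to a carbonyl group, and the measured step is a number 7.3 percentage points lower from compound 1 to compound 2 (within the scatter). Compound 3 differs from compound 1 by propyl in place of hydrogen on a saturated chain carbon, four bonds along the chain from an oxygen next to a carbonyl group, with the step of a number 5.3 percentage points lower from compound 1 to compound 3 (within the scatter). From compound 2 to compound 3 the step is a number 2 percentage points higher from compound 2 to compound 3 (within the scatter). None of these three steps reaches beyond the scatter.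

Compound 4, `CCCCCCCCOC(=O)CCC(=O)N1CCN(CCCOc2cc3c(Nc4ccc(F)c(Cl)c4)ncnc3cc2OC)CC1`, has not yet been measured in this assay. It differs from compound 3 by methyl in place of hydrogen on a saturated chain carbon, seven bonds along the chain from an oxygen next to a carbonyl group. This is the same kind of change as from compound 1 to compound 2, but not the same change: there the methyl entered four bonds along the chain from the oxygen, here seven bonds along. The step is expected to be small because a number 7.3 percentage points lower from compound 1 to compound 2 (within the scatter) lay within the scatter and the longer chain of compound 3 changed little. The expected step is a number 1.1 percentage points lower from compound 3 to compound 4 (within the scatter). Compound 4 is thus estimated at 88%, likely between 78% and 97%.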

Compound 4, a percentage reported as activity, at one concentration (the size of the read-out at that concentration, not a potency): 87.3%
Compound 4: the middle estimate sits 0.7 percentage points above what was measured; the measured number falls inside the stated range.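

In this assay, the new compound gives three steps: a number 1.8 percentage points lower from compound 3 to compound 4 (within the scatter), a number 0.2 percentage points higher from compound 2 to compound 4 (within the scatter) and a number 7.1 percentage points lower from compound 1 to compound 4 (within the scatter). Adding a methyl to the end of the chain reads alike on the two shorter and longer starting compounds: the same change on two cores in this assay, a number 7.3 percentage points lower (within the scatter) from compound 1 to compound 2 and a number 1.8 percentage points lower (within the scatter) from compound 3 to compound 4, 5.5 percentage points apart, within the scatter of two such steps Adding a propyl also reads alike, but with every step this small, the agreement shows only that none of these chain changes stands out from the noise, not that a real effect carries over from one core to another: the same change on two cores in this assay, a number 5.3 percentage points lower (within the scatter) from compound 1 to compound 3 and a number 0.2 percentage points higher (within the scatter) from compound 2 to compound 4, 5.5 percentage points apart, within the scatter of two such steps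

All four compounds shown are straight-chain esters on the shared core, so they leave open whether a branched chain, a much longer chain or a phenyl ring at the chain end would give a step beyond the scatter. They also leave open what a carboxylic acid or an amide in place of the ester would do in this assay.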